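The source may hold more compounds than are shown below. What is called first, only, known or untested is meant among the compounds shown, and "the series" means these compounds.

Measured compounds:
compound 1 `c1cc(OC2CCCCC2)nc(N2CCNCC2)c1` — 30 mg/kg
compound 2 `COc1cccc(N2CCNCC2)n1` — 30 mg/kg
compound 3 `CC(C)Oc1cccc(N2CCNCC2)n1` — 30 mg/kg

In a functional assay on the whole organism with Mus musculus as the target, in the maximal electroshock model, with a stated time of 30 min (a higher number here means that more compound is needed for the effect, a lower number that less compound is needed), compound 3 gives 30 mg/kg, and stands level with compound 1 and compound 2 at the digits shown; the steps of no change at the digits printed from compound 1 to compound 3 (within the scatter) and no change at the digits printed from compound 2 to compound 3 (within the scatter) are both within the scatter. The only variation across the three is the group on the oxygen on the aromatic ring, and the step of no change at the digits printed from compound 1 to compound 2 (within the scatter) shows that exchanging methyl and cyclohexyl there also leaves the read-out unchanged within the scatter.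

Compound 4 `CC(C)COc1cccc(N2CCNCC2)n1` continues the same series. The change is isobutyl in place of isopropyl on an oxygen on an aromatic ring. All three measured steps bear on it, since each exchanges one alkyl group for another on the same oxygen, and none of them moved the read-out beyond the scatter. The step of no change at the digits printed from compound 3 to compound 4 (within the scatter) is therefore expected to stay within the scatter, with no direction to it. Compound 4 is expected to give 30 mg/kg, within a range from 15 mg/kg to 60 mg/kg.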

Compound 4, minimum effective dose: 10 mg/kg
Compound 4: the middle estimate sits 3.0-fold (0.48 log units) above what was measured; measured number outside the range, below it.
By their numbers in this assay, from the lowest: compound 4; then compounds 1, 2 and 3 (each within the scatter of the next).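

Working notes: in this assay the group on the oxygen on an aromatic ring now moves the read-out beyond the scatter, as isobutyl in place of isopropyl gives (a 3.0-fold lower number from compound 3 to compound 4 (0.48 log units; beyond the scatter)), a modest step. Isobutyl also stands apart from the other two groups (a 3.0-fold lower number from compound 2 to compound 4 (0.48 log units; beyond the scatter); a 3.0-fold lower number from compound 1 to compound 4 (0.48 log units; beyond the scatter)), so this position does respond to the choice of alkyl group, although methyl, isopropyl and cyclohexyl remain level with one another and do not follow any simple trend with group size. No supporting data bear on why this one change has an effect.

From the compounds shown here alone, whether a longer chain such as n-pentyl, or a benzyl group, on the same oxygen would extend this step or lose it remains open. Also open, going by these compounds, is whether an amine at the end of such a chain would be tolerated.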